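Chain change from compound 3 to compound 4

A few compounds are considered here, and "the series" means these few. Any claim that something is new, unique, unknown or untested is made for them only; others in the source may bear on it.

Compound 3 `COC(=O)CCCCCCCCCCCCCC/C=C1\CC(CO)(COC(=O)C(C)(C)C)OC1=O` stands at > 10 ug/mL in a functional assay on Hs-578T cells (Homo sapiens) for antiproliferative activity (a lower number here means a stronger inhibitor of growth, a higher number a weaker inhibitor of growth), which is a limit and not a number.

Compound 4 `CCCCCOCCCCCCC/C=C1\CC(CO)(COC(=O)C(C)(C)C)OC1=O` carries pentyloxy in place of 7-(methoxycarbonyl)heptyl on a saturated chain carbon, seven bonds along the chain from a double-bonded chain carbon.

In this assay compound 1 `COCCCCCCCCCCCCCCC/C=C1\CC(CO)(COC(=O)C(C)(C)C)OC1=O` gives 5.45 ug/mL and compound 2 `COCCCCCCCCCCC/C=C1\CC(CO)(COC(=O)C(C)(C)C)OC1=O` gives 7.34 ug/mL, with a 1.3-fold higher number from compound 1 to compound 2 (0.13 log units; within the scatter).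

The steps bearing on the loss of methoxycarbonyl are an at least 1.8-fold higher number from compound 1 to compound 3 (0.26 log units; that floor lies within the scatter) and an at least 1.3-fold higher number from compound 2 to compound 3 (0.13 log units; that floor lies within the scatter), both small floors.

Compound 4 lacks methoxycarbonyl, as do compound 1 and compound 2, so a value near theirs is expected.

The expected step is an at least 1.5-fold lower number from compound 3 to compound 4 (0.18 log units; that floor lies within the scatter), with nothing firm beyond the scatter.

For compound 4 the estimate is 6.5 ug/mL, with an expected range of 3.5 ug/mL to 12 ug/mL.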

Compound 4, concentration for 50% growth inhibition: 3 ug/mL
Compound 4: middle estimate off by 2.2-fold (0.34 log units), on the high side, outside the stated range (below it).
By their numbers in this assay, from the lowest: compounds 4, 1 and 2 (each within the scatter of the next, the first and the last beyond it). At a limit, above all of these: compound 3.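

In this assay, among the compounds shown here, pentyloxy on a saturated chain carbon, seven bonds along the chain from a double-bonded chain carbon, gives a 2.4-fold lower number from compound 2 to compound 4 (0.39 log units; beyond the scatter), the only step between two measured numbers that lies beyond the scatter, while a 1.8-fold lower number from compound 1 to compound 4 (0.26 log units; within the scatter) stays within it. The step of an at least 3.3-fold lower number from compound 3 to compound 4 (0.52 log units; beyond the scatter) is the only floor that clears the scatter. Compound 3 stands at a limit and not a number: the limit of > 10 ug/mL in this assay, at which 1 of the 4 values shown sits.

Compound 4 changes the place of the chain oxygen and the chain end together, and the compounds shown do not separate the two. As far as these compounds go, a longer alkoxy chain at this place, or a carboxylic acid or an amine at the chain end, remains open.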